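Stereoisomer of a furan-bearing butenolide: expected cytotoxicity

The source may hold more compounds than are shown below. What is called first, only, known or untested is meant among the compounds shown, and "the series" means these compounds.

Two compounds were tested in a functional assay on HCT-15 cells (Homo sapiens) for cytotoxicity; on this read-out lower numbers stand for an effect already at smaller amounts and higher numbers for an effect only at larger amounts of compound. Compound 1 `CC1=C(O)[C@@H](C/C(C)=C\CCC(C)/C=C/C=C(\C)CCCc2ccoc2)OC1=O` gives 27.2 ug/mL in this assay. Compound 2 `CC1=C(O)[C@@H](C/C(C)=C\CCC(C)/C=C/C/C(C)=C/CCc2ccoc2)OC1=O` gives 27.5 ug/mL in this assay. Compound 1 has the lower of these two numbers, but compound 2 lies within the usual scatter of it, so the two cannot be told apart on this evidence.

Compound 3 `CC1=C(O)[C@H](C/C(C)=C\CCC(C)/C=C\C=C(\C)CCCc2ccoc2)OC1=O` has not yet been measured. It contains exactly the same atoms and bonds as compound 1 and differs only in how the structure is drawn in space: the two compounds have the same atoms and bonds; at least one stereo element is drawn with a configuration in one of them and without one in the other: 3 of 5 stereo elements differ; a stereocentre at a saturated ring carbon is drawn R in compound 1 and S in compound 3; a double bond is drawn E in compound 1 and Z in compound 3; a double bond is drawn E in compound 1 and Z in compound 3. For the measured compounds named here, no pair of measured compounds here differs by a change of this kind, so no measured step can be used to predict the effect of altering the drawn configuration of a ring stereocentre and two double bonds.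

Given that the only two numbers available, for compound 1 and compound 2, sit within the scatter of each other, the step from compound 1 to compound 3 is expected to be no larger than the scatter, a 1.1-fold higher number from compound 1 to compound 3 (0.04 log units; within the scatter), in either direction. In this assay compound 3 is therefore estimated to give about 30 ug/mL, plausibly between 12 ug/mL and 80 ug/mL.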

Compound 3, concentration for half-maximal effect: 8.95 ug/mL
The estimate for compound 3 lay 3.4-fold (0.53 log units) above the measured number; measured number outside the range, below it.
By their numbers in this assay, from the lowest: compound 3; then compounds 1 and 2 (each within the scatter of the next).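

The earlier compounds shown here included no change in drawn configuration, so they said nothing about its effect. Here the atoms and bonds stay the same, yet in this assay the change in how the structure is drawn in space gives a 3.0-fold lower number from compound 1 to compound 3 (0.48 log units; beyond the scatter), showing that the cytotoxicity read-out can shift with no group entering or leaving. The step bundles three stereo elements, the ring stereocentre going from R to S and two double bonds going from E to Z, and its reading is further limited by one point: the fact that one of compounds 1 and 3 is drawn with a defined configuration and the other without, at the place where they differ

The compounds shown leave open which of the three stereo elements accounts for the step, or whether it takes them together, as no pair here changes just one of them. Also open, as far as these compounds go, is whether a similar shift would appear if the furan at the end of the chain gave way to a carboxylic acid or an amine, or if the chain were longer.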